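Compound 3: an aryl swap on a weak antiproliferative series

This account rests on a few compounds, and the source may have more. Where it says the series, first, only, none or still open, it means among the compounds named here.

In an ADME assay on MRC5 cells (Homo sapiens) for antiproliferative activity, read by fluorescence and resazurin assay, with a stated time of 68 h (a higher number here means that more compound is needed for the effect, a lower number that less compound is needed), compound 1 `O=C(NCCN1CCCC1)c1cc(N2CCn3ccnc3C2)nc2ccc(F)cc12` gives > 50000 nM, which is a limit of the assay and not a number. That places compound 1 at the limit of > 50000 nM in this assay, at which 1 of the 2 values shown sits. Among the compounds with values here, the only actual number so far comes from compound 2 `O=C(NCCN1CCCC1)c1cc(NCCC2CCOCC2)nc2ccc(Cl)cc12`, which gives 31000 nM in this assay. Compound 2 differs from compound 1 in more than one place, so the pair isolates no single change.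

Compound 3 `CN(C)c1ccc(-c2cc(C(=O)NCCN3CCCC3)c3cc(F)ccc3n2)cc1` keeps the core of compound 1 and changes one group: a group of 9 heavy atoms (8 carbon, 1 nitrogen; one six-membered aromatic ring of carbon only) in place of a group of 9 heavy atoms (6 carbon, 3 nitrogen; one five-membered aromatic ring with 2 hetero atoms, one six-membered non-aromatic ring with 2 hetero atoms), on an aromatic carbon. The new 4-(dimethylamino)phenyl group sits on the aromatic carbon next to the ring nitrogen. Within the data shown here, no measured pair shows what this change does in this assay, so any forecast is loose. With compound 2 at 31000 nM as the sole anchor, a modest move toward less compound needed seems the likeliest direction. A second limit remains possible for compound 3. The expected size of the change is an at least 3.3-fold lower number from compound 1 to compound 3 (0.52 log units; beyond the scatter), an estimate that inherits the uncertainty of the limit. For compound 3 the estimated value is 15000 nM, with an expected range of 4000 nM to 50000 nM.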

Compound 3, half-maximal effective concentration: 10000 nM
Compound 3: middle estimate off by 1.5-fold (0.18 log units), on the high side; low and high end bracket the measured number.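

In this assay, 4-(dimethylamino)phenyl on the aromatic carbon next to the ring nitrogen, in place of the group with a five-membered aromatic ring and a six-membered non-aromatic ring, gives an at least 5.0-fold lower number from compound 1 to compound 3 (0.69 log units; beyond the scatter). Within the data shown here, this is the first reading of this position on its own: compound 1 and compound 2 differ in more than one place and isolate no single change, whereas this pair shows that the group on this carbon alone can shift the read-out beyond the scatter. From the compounds shown here alone, the true size of the step stays unknown, as the figure for compound 1 is a limit of the assay and not a number: the limit of > 50000 nM in this assay, at which 1 of the 3 values shown sits.

A single pair cannot separate the parts of this swap, which alters the ring types, the carbon and nitrogen counts and the hydrogen-bond acceptor count together, and it gives no cause for the step. Also open, going by these compounds, is whether the phenyl ring or its dimethylamino substituent carries the step, a question that an unsubstituted phenyl or a 4-methoxyphenyl on the same carbon, with the rest of compound 3 unchanged, would address.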